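The source may report more compounds than this note shows. Statements on the series, on what has been measured and on what is new or still open speak of the compounds shown alone.

Compound 1 `COc1cc(-n2ncnc2-c2ccc(Cl)cc2)cc(OC)c1OC`: > 10000 nM, a limit.
Compound 2 `COc1cc(-n2ncnc2-c2ccccc2)cc(OC)c1OC`: > 10000 nM, a limit.

Both entries come from a functional assay on HeLa cells (Homo sapiens) for antiproliferative activity, read by MTT assay, with a stated time of 72 h (a higher number here means a weaker inhibitor, a lower number a stronger inhibitor), and neither is a number: the limit of > 10000 nM in this assay, at which 2 of the 2 values shown sit. Compound 2 therefore stands only at a limit. Compound 3 `COc1cc(-n2ncnc2-c2ccc(OC(C)C)cc2)cc(OC)c1OC` differs from compound 2 by isopropoxy in place of hydrogen on an aromatic carbon. Going by the values given here, the one measured step, a step that the two limits leave unreadable from compound 1 to compound 2, changes the same aromatic carbon but has no readable size, so it supplies neither a size nor a direction. No change beyond the scatter is expected in this assay, and the estimated step is a number no higher from compound 2 to compound 3 (the limit leaves the size open). Compound 3 is expected at 10000 nM, with an estimated range of 1000 nM to 30000 nM.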

Compound 3, half-maximal inhibitory concentration: 600 nM
Estimate against measurement, compound 3: 17-fold (1.22 log units) above; the measured number lies below the stated range.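

Replacing hydrogen with isopropoxy gives an at least 16-fold lower number from compound 2 to compound 3 (1.22 log units; beyond the scatter) on the aromatic carbon para to a large group, and replacing chloro gives an at least 16-fold lower number from compound 1 to compound 3 (1.22 log units; beyond the scatter) at the same carbon. The read-out in this assay thus responds to the group at this carbon, which the step between compound 1 and compound 2, unreadable between two limits, could not show.

From the compounds shown here alone, whether an ethoxy group, a longer alkoxy chain or an amine at this carbon would do the same stays open. The full size of both steps also stays open, as each starts from a limit: the limit of > 10000 nM in this assay, at which 2 of the 3 values shown sit.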